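A few compounds are considered here, and "the series" means these few. Any claim that something is new, unique, unknown or untested is made for them only; others in the source may bear on it.

Measured in a functional assay on Bel-7402 cells (Homo sapiens) for cytotoxicity, read by MTT assay, with a stated time of 72 h; a lower number here means a stronger inhibitor, a higher number a weaker inhibitor:
- compound 1 `C=C1C(=O)[C@@]23C(=O)OC[C@]4([C@@H](OC(C)=O)CCC(C)(C)[C@H]4C=O)[C@@H]2CC[C@@H]1[C@H]3O`: 75400 nM
- compound 2 `C=C1C(=O)[C@@]23C(=O)OC[C@]4(C(=O)CCC(C)(C)[C@H]4C=O)[C@@H]2CC[C@@H]1[C@H]3OC(C)=O`: 1730 nM

Only these two numbers are available so far. Compound 2, at 1730 nM, holds the lower one and is therefore the stronger inhibitor of the pair. Compound 1, at 75400 nM, lies higher by a gap well beyond the usual scatter of repeated measurements.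

The next compound to be tested is compound 3 `C=C1C(=O)[C@@]23C(=O)OC[C@]4(C(=O)CCC(C)(C)[C@H]4C=O)[C@@H]2CC[C@@H]1[C@H]3OC(=O)c1ccccc1`. It keeps the rest of compound 2 but has phenyl in place of methyl on a carbonyl carbon, which turns acetoxy into benzoyloxy: phenyl in place of methyl on a carbonyl carbon. Among the measured compounds shown here, no pair of measured compounds differs in only one place, so the data do not show directly what a swap like this does in this assay. The expectation therefore stays anchored on compound 2 at 1730 nM, with no firm direction and a wide range.

The expected change is a 1.2-fold higher number from compound 2 to compound 3 (0.06 log units; within the scatter), which would be no step beyond the scatter. In this assay the estimate for compound 3 is 2000 nM, with an expected range from 600 nM to 7000 nM.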

Compound 3, half-maximal inhibitory concentration: 1850 nM
For compound 3 the middle estimate is 1.1-fold (0.03 log units) above the measured one, within the range that was stated.
By their numbers in this assay, from the lowest: compounds 2 and 3 (each within the scatter of the next); then compound 1.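

In this assay, putting phenyl in place of methyl on a carbonyl carbon, which turns acetoxy into benzoyloxy, gives a 1.1-fold higher number from compound 2 to compound 3 (0.03 log units; within the scatter) and so stays inside the usual scatter. Among the compounds shown here, this is the first pair that differs in one place only, and so the first direct look at what this position does: a group of 6 heavy atoms with an aromatic ring replaces a single carbon, yet the two numbers cannot be told apart. No measurement at hand bears on why the two compounds read alike.

With only methyl and phenyl shown on this carbonyl carbon, one pair cannot tell whether the position accepts groups in general or whether these two simply happen to match. Still open, going by these compounds, is how the cells respond to a longer chain such as butyl there, or to a phenyl ring carrying an amine or a carboxylic acid, either of which would show whether the read-out stays level once the new group differs more from these two.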